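A few compounds are considered here, and "the series" means these few. Any claim that something is new, unique, unknown or untested is made for them only; others in the source may bear on it.

Measured so far in a functional assay on SGC-7901 cells (Homo sapiens) for inhibition, read by MTT assay, with a stated time of 24 h; on this read-out higher numbers stand for weaker inhibition and lower numbers for stronger inhibition:
- Compound 1 `CC1(C)[C@H]2CC[C@]1(C)N(Cc1cn(-c3ccc(O)cc3)nn1)C(=O)C2` gives 330 nM
- Compound 2 `COc1cccc(-n2cc(CN3C(=O)C[C@@H]4CC[C@@]3(C)C4(C)C)nn2)c1` gives 590 nM

With only these two numbers available, compound 2 at 590 nM has a single neighbour, compound 1, and the two lie within the usual scatter of each other.

The next compound, compound 3 `COc1ccc(-n2cc(CN3C(=O)C[C@@H]4CC[C@@]3(C)C4(C)C)nn2)cc1`, has not been measured yet. It has the same atoms as compound 2, joined differently, with 4-methoxyphenyl in place of 3-methoxyphenyl on an aromatic nitrogen. For the measured compounds named here, the only measured step that bears on this change is a 1.8-fold higher number from compound 1 to compound 2 (0.25 log units; within the scatter). That step exchanged 4-hydroxyphenyl for 3-methoxyphenyl on the same aromatic nitrogen, and it stayed within the scatter. Going by the values given here, no measured pair shows what shifting the methoxy group alone does, so the evidence is thin and no direction can be favoured with confidence.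

In this assay no change beyond the scatter is expected, and the estimated step is a 1.3-fold lower number from compound 2 to compound 3 (0.12 log units; within the scatter). For compound 3 the expected value is 450 nM, with an estimated range of 190 nM to 1000 nM.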

Compound 3, half-maximal inhibitory concentration: 480 nM
Beside the measured number, compound 3's estimate is 1.1-fold (0.03 log units) below it; the range from low to high includes it.
By their numbers in this assay, from the lowest: compounds 1, 3 and 2 (each within the scatter of the next).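

For the compounds shown here, exchanging 3-methoxyphenyl for 4-methoxyphenyl on the aromatic nitrogen in this assay gives a 1.2-fold lower number from compound 2 to compound 3 (0.09 log units; within the scatter) and isolates the place of the methoxy group for the first time, showing that this shift leaves the two compounds indistinguishable within the scatter. Putting methyl in place of hydrogen on the oxygen of the 4-hydroxyphenyl group gives a 1.5-fold higher number from compound 1 to compound 3 (0.16 log units; within the scatter) and adds a second direct comparison, so a hydroxyl and a methoxy group in the same ring position also cannot be told apart in this assay. Nothing measured here offers an explanation for how close these three compounds lie.

As far as these compounds go, all three compounds carry an oxygen on the phenyl ring, so it remains open whether an amine or a carboxylic acid there, an unsubstituted phenyl ring, or a longer chain in place of the ring would produce a step beyond the scatter. Also open, from the compounds shown here alone, are the value for 3-hydroxyphenyl, which would complete the comparison of both oxygen groups at both ring positions, and whether the same closeness would hold with a different shared core.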